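This account rests on a few compounds, and the source may have more. Where it says the series, first, only, none or still open, it means among the compounds named here.

Compound 1, `Nc1nc(NC2CCCCC2)c2ncn(/C=C3/CC3(CO)CO)c2n1`: > 24000 nM
Compound 2, `CCCNc1nc(N)nc2c1ncn2/C=C1/CC1(CO)CO`: > 24000 nM
Compound 3, `CCCOc1nc(N)nc2c1ncn2/C=C1/CC1(CO)CO`: > 20000 nM

In an ADME assay on Akata cells (Homo sapiens) for cytotoxicity, with a stated time of 7 days (a lower number here means that less compound is tolerated, a higher number that more compound is tolerated), compound 1 gives > 24000 nM, which is a limit of the assay rather than a number. Compound 2 likewise gives > 24000 nM, also a limit. Compound 3 gives > 20000 nM, again a limit. None of the three measured steps can therefore be read: a step that the two limits leave unreadable from compound 1 to compound 2, a step that the two limits leave unreadable from compound 1 to compound 3 and a step that the two limits leave unreadable from compound 2 to compound 3 all stay hidden, because every value sits at the limit of > 24000 nM in this assay, at which 2 of the 3 values shown sit, or at the limit of > 20000 nM in this assay, at which 1 of the 3 values shown sits. Compound 1 thus stands at the top of what this assay reports, with no separation from compound 2 or compound 3.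

Compound 4, `Nc1nc(NC2CCCC2)c2ncn(/C=C3/CC3(CO)CO)c2n1`, differs from compound 1 in one place: cyclopentyl in place of cyclohexyl on a nitrogen on an aromatic ring. Among the measured compounds shown here, no measured step bears directly on this change, and the two steps that start from compound 1 are both unreadable. The step is expected to be a step that the limit leaves unreadable from compound 1 to compound 4, with no movement beyond the scatter. Compound 4 is therefore expected to give 30000 nM, within 15000 nM to 80000 nM, most probably reported once more only as a limit.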

Compound 4, half-maximal cytotoxic concentration: > 20000 nM
Compound 4: a limit, no number (the forecaster's own chance of this, stated with the estimate: 85%); the middle value is on the limit's open side.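

In this assay compound 4 gives > 20000 nM, a limit and not a number, and its steps from compound 1, compound 2 and compound 3 cannot be read. The compounds shown leave open at what concentration any of the four becomes cytotoxic, and whether they differ at all.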